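Triazole hydroxamates: inverting a ring stereocentre

This account rests on a few compounds, and the source may have more. Where it says the series, first, only, none or still open, it means among the compounds named here.

Measured so far:
compound 1 `O=C(NO)c1ccc(-c2cn([C@@H]3C[C@H](CO)N(Cc4ccccc4)C3)nn2)cc1` — 14%
compound 2 `O=C(NO)c1ccc(-c2cn([C@@H]3C[C@H](C(=O)O)N(Cc4ccccc4)C3)nn2)cc1` — < 10%
compound 3 `O=C(NO)c1ccc(-c2cn([C@@H]3C[C@H](CO)N(CCCc4ccccc4)C3)nn2)cc1` — 15%

In an assay on Sf9 cells for inhibition of histone deacetylase 11 (Homo sapiens), read by fluorescence, tested at 0.5 uM (a higher number here means more inhibition at the concentration tested (going by the name of the read-out), a lower number less inhibition), compound 1 gives 14%. Among the two numbers reported, compound 1 has the lower, but its nearest neighbour is compound 3 with 15%, and the step of a number 1 percentage points higher from compound 1 to compound 3 (within the scatter) lies within the scatter, so the two cannot be ordered. Compound 2 reads < 10%, which is a limit of the assay and not a number. Among the measured compounds shown here, the step of a number at least 4 percentage points lower from compound 1 to compound 2 (that floor lies within the scatter) therefore has a floor that itself lies within the scatter, and the only evidence on it is the limit of < 10% in this assay, at which 1 of the 3 values shown sits.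

Compound 4 `O=C(NO)c1ccc(-c2cn([C@H]3C[C@H](CO)N(Cc4ccccc4)C3)nn2)cc1` is not yet measured. Its relation to compound 1: the two compounds have the same atoms and bonds and differ only in configuration as drawn: 1 of 2 stereo elements differ; a stereocentre at a saturated ring carbon is drawn R in compound 1 and S in compound 4. Neither measured step touches configuration: one replaces hydroxymethyl by carboxy on the saturated ring carbon, the other phenyl by phenethyl on the chain carbon bound to the ring amine nitrogen. For the measured compounds named here, no measured step bears on an inversion at the ring carbon, so there is no basis for expecting a move beyond the scatter in either direction. The expected step is a number 2 percentage points lower from compound 1 to compound 4 (within the scatter). Compound 4 is estimated at 12%, in the range 4% to 22%.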

Compound 4, a percentage reported as inhibition, at one concentration (the size of the read-out at that concentration, not a potency): 16%
The estimate for compound 4 lay 4 percentage points below the measured number; the range from low to high includes it.
By their numbers in this assay, from the lowest: compounds 1, 3 and 4 (each within the scatter of the next). At a limit, below all of these: compound 2.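

Inversion at the saturated ring carbon is the first change in the series that touches configuration, and in this assay the step is a number 2 percentage points higher from compound 1 to compound 4 (within the scatter). The comparison isolates configuration at this one centre, with the other stereocentre and every group held constant: the fact that compounds 1 and 4 differ only in the configuration as drawn. At the single concentration tested, the drawn configuration at this ring carbon therefore does not separate the two compounds, just as the chain change on the ring nitrogen does not in the step of a number 1 percentage points higher from compound 1 to compound 3 (within the scatter), though a reading at one concentration is not a potency and a difference could still lie hidden at these low levels of inhibition.

From the compounds shown here alone, whether the inversion would read the same with a carboxylic acid, a primary amine or an amide on the ring in place of hydroxymethyl stays open, as does the effect of inverting the second stereocentre or of placing a longer chain on the ring nitrogen of the inverted compound. For the carboxylic acid, compound 2 gives < 10%, which is a limit of the assay and not a number.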